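The source may hold more compounds than are shown below. What is called first, only, known or untested is meant among the compounds shown, and "the series" means these compounds.

Measured compounds:
compound 1 `Cc1ccc2nc(C(=O)Nc3c(F)cc(-c4cccc(F)c4)cc3F)c(C)c(O)c2c1`: 37.3%
compound 2 `CCc1ccc2nc(C(=O)Nc3c(F)cc(-c4cccc(F)c4)cc3F)c(C)c(O)c2c1`: 56.3%
compound 3 `Cc1c(C(=O)Nc2c(F)cc(-c3cccc(F)c3)cc2F)nc2ccc(F)cc2c1O`: 41.2%

All three were tested in a functional assay on Hep 3B2 cells (Homo sapiens) for antiproliferative activity, read by MTT assay, with a stated time of 24 h, tested at 33.33 ug/mL; on this read-out lower numbers stand for a weaker effect and higher numbers for a stronger effect at the one concentration tested. Compound 3 stands second highest of the three: its nearest neighbour is compound 1, which lies within the scatter of it, and its furthest is compound 2, which lies beyond the scatter above it.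

The step from compound 3 to compound 4 `CCOc1ccc2nc(C(=O)Nc3c(F)cc(-c4cccc(F)c4)cc3F)c(C)c(O)c2c1` is ethoxy in place of fluoro on an aromatic carbon. For the measured compounds named here, two measured steps touch the same position of the shared core. The step of a number 15.1 percentage points lower from compound 2 to compound 3 (beyond the scatter) shows that when ethyl is replaced by fluoro at this carbon the number falls by a modest amount, while a number 3.9 percentage points higher from compound 1 to compound 3 (within the scatter) shows that replacing methyl by fluoro changes little. Compound 4 reverses the direction of those steps, putting an ethoxy group, of a size close to ethyl, where fluoro sits in compound 3. Going by the values given here, a modest rise in this assay is therefore expected, roughly the size of the ethyl-to-fluoro step but in the opposite direction, though with only three compounds the expectation is loose.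

For compound 4 the estimated value is 52%, with a range from 36% to 66%. This corresponds to an expected step of a number 10.8 percentage points higher from compound 3 to compound 4 (beyond the scatter).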

Compound 4, a percentage reported as inhibition, at one concentration (the size of the read-out at that concentration, not a potency): 11.2%
The estimate for compound 4 lay 40.8 percentage points above the measured number; the measured number lies below the stated range.
By their numbers in this assay, from the lowest: compound 4; then compounds 1 and 3 (each within the scatter of the next); then compound 2.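

Ethoxy is the first group shown at this aromatic carbon to take the number well down in this assay, with a number 30 percentage points lower from compound 3 to compound 4 (beyond the scatter) and a number 26.1 percentage points lower from compound 1 to compound 4 (beyond the scatter) and the largest change of the set, a number 45.1 percentage points lower from compound 2 to compound 4 (beyond the scatter). Growing the substituent therefore does not steadily raise the number: methyl to ethyl gave a number 19 percentage points higher from compound 1 to compound 2 (beyond the scatter) but compound 4, with its ethoxy group, goes against any trend that links a larger group with a stronger effect. So a group of similar size can give a very different result here, and what sets ethoxy apart from ethyl in this assay cannot be explained from the information available.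

As far as these compounds go, it remains open whether the fall comes from the oxygen joined to the aromatic carbon or from the ethoxy group as a whole, a question that a methoxy group, a propyl chain or an amine at this carbon could help to settle. Each number also reflects a single concentration, so these results show only a stronger or weaker effect at that concentration.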